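From a Three-Membered Ring to a Four-Membered Ring

The source may report more compounds than this note shows. Statements on the series, on what has been measured and on what is new or still open speak of the compounds shown alone.

This study follows a small set of compounds through an in vitro ADME assay on microsomes from liver (Homo sapiens) for metabolic stability, tested at 5 uM; a higher number here means that the compound lasts longer, a lower number that the compound disappears faster. Compound 1, `CS(=O)(=O)Nc1ccc2c(c1)S(=O)(=O)N=C(c1c(O)c(-c3ccsc3)nn(CCC3CC3)c1=O)N2`, gives 0.517 h in this assay. Compound 2, `C/C(=C\c1nn(CCC(C)C)c(=O)c(C2=NS(=O)(=O)c3cc(NS(C)(=O)=O)ccc3N2)c1O)C(F)(F)F`, gives 0.167 h. Compound 3, `CS(=O)(=O)Nc1ccc2c(c1)S(=O)(=O)N=C(c1c(O)c(-c3cccs3)nn(CCC3CC3)c1=O)N2`, reaches a value that the assay reports only as a limit, > 1 h, so for compound 3 only a range is known, not a number. For the measured compounds named here, the one measured step, an at least 1.9-fold higher number from compound 1 to compound 3 (0.28 log units; that floor lies within the scatter), puts thiophen-2-yl in place of thiophen-3-yl, and its floor is set by the limit of > 1 h in this assay, at which 1 of the 3 values shown sits.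

Compound 4, `CS(=O)(=O)Nc1ccc2c(c1)S(=O)(=O)N=C(c1c(O)c(-c3cccs3)nn(CCC3CCC3)c1=O)N2`, differs from compound 3 in one place: cyclobutyl in place of cyclopropyl on a saturated chain carbon, two bonds along the chain from an aromatic nitrogen. Going by the values given here, none of the measured steps touches the saturated chain that carries this ring; the single step between compound 1 and compound 3 alters a different part of the molecule. The measured compounds therefore give no guide to the size or direction of this change, and the expectation is a step no larger than the scatter of repeated measurements. The half-life of compound 4 is expected to be 1.2 h, within a range from 0.6 h to 2.5 h. The expected step, a step that the limit leaves unreadable from compound 3 to compound 4, is thus estimated to stay within the usual scatter. Since compound 3 itself sits at a limit, the assay may again report only a limit for compound 4.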

Compound 4, half-life: > 1 h
Compound 4: a limit, no number (the forecaster's own chance of this, stated with the estimate: 60%); the middle value does not contradict the limit.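

No step can be read between compound 3 and compound 4 in this assay, because both stand at a limit and not at a number: the limit of > 1 h in this assay, at which 2 of the 4 values shown sit.

On these data alone, what remains open is how long the half-life of each of these two compounds really is, and whether cyclobutyl in place of cyclopropyl changes it at all.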